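Spiro series on the cholesterol transporter: tail truncation

The source may report more compounds than this note shows. Statements on the series, on what has been measured and on what is new or still open speak of the compounds shown alone.

Compound 1 `CC(C)(C)c1ccc(C(=O)N2CCC3(CC2)C(=O)N(CC(=O)NCCCCCNS(C)(=O)=O)CN3c2ccccc2)cc1` and compound 2 `CC(C)(C)OC(=O)NCCCCNC(=O)CN1CN(c2ccccc2)C2(CCN(C(=O)c3ccc(C4CCCCC4)cc3)CC2)C1=O` are the measured pair in an assay on HEK293 cells for displacement of a labelled ligand from NPC1-like intracellular cholesterol transporter 1 (Homo sapiens); on this read-out higher numbers stand for weaker inhibition and lower numbers for stronger inhibition. In this assay compound 1 gives 5500 nM, and compound 2 gives 4600 nM; the two values lie within the usual scatter of each other, so neither is separable from the other. Going by the values given here, no step between measured compounds is known, so the series offers no precedent for changes at this chain end.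

Compound 3 `CC(C)(C)c1ccc(C(=O)N2CCC3(CC2)C(=O)N(CC(=O)NCCCCO)CN3c2ccccc2)cc1` carries the difference (hydroxy in place of (methanesulfonamido)methyl on a saturated chain carbon, four bonds along the chain from an amide-type nitrogen). With no guide from the measured pair, the step of a 1.4-fold higher number from compound 1 to compound 3 (0.13 log units; within the scatter) from compound 1 to compound 3 is expected to be small, at most modestly toward weaker inhibition. Compound 3 is estimated at 7500 nM, with a range of 2500 nM to 22000 nM.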

Compound 3, half-maximal inhibitory concentration: 19200 nM
Estimate against measurement, compound 3: 2.6-fold (0.41 log units) below; low and high end bracket the measured number.
By their numbers in this assay, from the lowest: compounds 2 and 1 (each within the scatter of the next); then compound 3.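

Going from (methanesulfonamido)methyl to hydroxy gives a 3.5-fold higher number from compound 1 to compound 3 (0.54 log units; beyond the scatter) and is the first step readable in the series: a modest move toward weaker inhibition. This chain end is therefore not indifferent to what it carries, as the measured pair alone could not show. No measurement at hand accounts for the step.

As far as these compounds go, the change replaces the end group and shortens the chain together, so the share of each stays open. A longer chain ending in hydroxy, or an amine or a carboxylic acid at this end, would help separate them.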